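The compounds below may be only part of what the source reports. "The series", "measured", "known", "first", "only" and "open" are said of these compounds alone.

The study measures positive allosteric modulation in an assay on HEK293 cells for positive allosteric modulation of metabotropic glutamate receptor 2 (Rattus norvegicus), read by thallium flux, with a stated time of 2.5 min; a higher number here means a larger maximal response, a lower number a smaller maximal response. Of the compounds shown here, three have been measured. Compound 1, `Cc1c(OCCCCOc2ccc(F)c(C(=O)O)c2)ccc(C(=O)CC(C)(C)C)c1O`, reaches 94.6% in this assay. Compound 3, `Cc1c(OCCCCOc2ccc(C(=O)CC(C)(C)C)c(O)c2C)cccc1C(=O)O`, reaches 95.8% in this assay. Compound 2, `CCC(=O)c1ccc(OCCCCOc2cccc(C(=O)O)c2C)c(C)c1O`, reaches 71.3% in this assay.

Compound 3 and compound 2 differ in one place: methyl in place of tert-butyl on a saturated chain carbon bound to a carbonyl carbon. That change produced a number 24.5 percentage points lower from compound 3 to compound 2 (beyond the scatter). Compound 1 and compound 3 differ only in the aryl group on the other end of the chain: 3-carboxy-4-fluorophenyl in place of 3-carboxy-2-methylphenyl on an oxygen on a saturated carbon. Here the two values lie close together, with a number 1.2 percentage points higher from compound 1 to compound 3 (within the scatter), so the two cores cannot be told apart on this read-out.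

The unmeasured compound 4, `CCC(=O)c1ccc(OCCCCOc2ccc(F)c(C(=O)O)c2)c(C)c1O`, stands to compound 1 as compound 2 stands to compound 3. The difference is methyl in place of tert-butyl on a saturated chain carbon bound to a carbonyl carbon. The place of the change is described in the same words for both pairs, so this is the same change made on the core of compound 1 rather than on the core of compound 3. Since the two cores gave near-equal values, the expectation is that the change will act as it did before, with the step seen in a number 24.5 percentage points lower from compound 3 to compound 2 (beyond the scatter) as the guide. The expected step is a number 24.6 percentage points lower from compound 1 to compound 4 (beyond the scatter). Compound 4 is therefore estimated at 70%, with a likely range from 57% to 84%.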

Compound 4, largest response reached (reported as percent of maximum), in percent of the reference or control that the assay uses: 66.6%
The estimate for compound 4 lay 3.4 percentage points above the measured number; the measured number falls inside the stated range.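

In this assay, methyl in place of tert-butyl on a saturated chain carbon bound to a carbonyl carbon gave, on the core of compound 1, a number 28 percentage points lower from compound 1 to compound 4 (beyond the scatter). Set beside the earlier step on the core of compound 3, the change carried over from one core to the other with no size difference that can be told from the scatter: the same change on two cores in this assay, a number 24.5 percentage points lower (beyond the scatter) from compound 3 to compound 2 and a number 28 percentage points lower (beyond the scatter) from compound 1 to compound 4, 3.5 percentage points apart, within the scatter of two such steps

Among these compounds, this shows only that the change travelled across this one pair of cores, which differ solely in the carboxy-bearing aryl group and reached near-equal values with tert-butyl in place, and it does not show that the same step would appear on a core further removed from these. It also concerns the largest response alone, so it says nothing about the concentration needed to reach that response, nor about why the response falls.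

The compounds shown leave open how the response behaves with groups of intermediate or different shape at that place, such as isopropyl or cyclohexyl. They also leave open whether the step would persist with an amide in place of the carboxylic acid, or with a shorter or longer chain linking the two aryl ends.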